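The compounds below may be only part of what the source reports. "The series", "measured", "known", "first", "only" and "open" are said of these compounds alone.

Two compounds from this series have been run in a functional assay for agonist activity at G protein-coupled receptor 88 (Homo sapiens), read by HTRF and cAMP accumulation; a higher number here means that more compound is needed for the effect, a lower number that less compound is needed. Compound 1 `CC(C)C[C@H](N)CN(C(=O)C(C)Cc1ccccc1)c1ccc(-c2ccccc2)cc1` gives 1.2 nM in this assay. Compound 2 `CC[C@H](C)[C@H](N)CN(C(=O)[C@@H]1C[C@H]1c1cccc(C#N)c1)c1ccc(-c2ccccc2)cc1` gives 1600 nM in this assay, which is the higher of the two numbers and lies far beyond the usual scatter from compound 1. Compound 2 is therefore the starting point for the step considered here, and it already needs much more material than compound 1 to produce the same effect.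

Compound 3 `CC[C@H](C)[C@H](N)CN(C(=O)[C@@H]1C[C@H]1c1csc(C)n1)c1ccc(-c2ccccc2)cc1` has not yet been measured. It keeps the whole core of compound 2 and differs in one place: 2-methyl-1,3-thiazol-4-yl in place of 3-cyanophenyl on a saturated ring carbon. Going by the values given here, no pair of measured compounds shows what such a swap does, so there is no measured step to lean on. The expectation for this assay is a step of a 1.6-fold higher number from compound 2 to compound 3 (0.19 log units; within the scatter) from compound 2 to compound 3 that stays within or close to the usual scatter, with no clear direction. On that basis compound 3 is estimated at 2500 nM in this assay, with a range from 600 nM to 10000 nM.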

Compound 3, half-maximal effective concentration: 1500 nM
Beside the measured number, compound 3's estimate is 1.7-fold (0.22 log units) above it; the measured number falls inside the stated range.
By their numbers in this assay, from the lowest: compound 1; then compounds 3 and 2 (each within the scatter of the next).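

Going by these compounds alone, the step of a 1.1-fold lower number from compound 2 to compound 3 (0.03 log units; within the scatter) in this assay gives the first measured reading of a swap at this position: on this saturated ring carbon, 2-methyl-1,3-thiazol-4-yl and 3-cyanophenyl cannot be told apart. The match holds although the two groups differ clearly in make-up, with a five-membered aromatic ring with 2 hetero atoms and 6 heavy atoms entering, and a six-membered aromatic ring of carbon only with a triple bond and 8 heavy atoms leaving. Nothing measured on these compounds offers a reason for this match.

Going by these compounds, two groups cannot show how much freedom this ring carbon allows, and it remains open whether a plain phenyl, a pyridine ring, or a group carrying an amine or a carboxylic acid in the same place would give a clearly different number. Compound 2 and compound 3 differ from compound 1 in more than one place, so the result for compound 1 of 1.2 nM cannot be tied to any single group.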